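This account rests on a few compounds, and the source may have more. Where it says the series, first, only, none or still open, it means among the compounds named here.

In a functional assay on NCI-H23 cells (Homo sapiens) for cytotoxicity, read by sulforhodamine B assay, with a stated time of 72 h (on this read-out higher numbers stand for weaker inhibition of growth and lower numbers for stronger inhibition of growth), compound 1 `O=C(Nc1ccc(C(F)(F)F)cc1)C1CCc2ccccc2N1` gives a measured number, 25800 nM. Compound 2 `CCCC(=O)N1c2ccccc2CCC1C(=O)Nc1ccccc1C(F)(F)F` reads > 70000 nM, which is a limit of the assay and not a number. Compound 2 therefore has no exact position on this scale, and any step away from it has to be judged with care.

The next compound, compound 3 `O=C(Nc1ccccc1C(F)(F)F)C1CCc2ccccc2N1C(=O)c1ccccc1`, has not yet been measured. It differs from compound 2 in a single place, the group on a carbonyl carbon whose other neighbours are: amide-type nitrogen in a ring. There, phenyl stands in place of propyl, so that propylcarbonyl becomes benzoyl: phenyl in place of propyl on a carbonyl carbon.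

Among the measured compounds shown here, no measured pair shows what this swap does, so the forecast has little to lean on. The starting point is compound 2, with its limit of > 70000 nM, and nothing in hand points to a large gain in growth inhibition. The expected result is a small change, no larger than the usual scatter of repeated measurements, and a second limit would be no surprise: an at least 1.1-fold lower number from compound 2 to compound 3 (0.06 log units; that floor lies within the scatter). The estimated value for compound 3 is 60000 nM, with an expected range from 20000 nM to 120000 nM.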

Compound 3, concentration for 50% growth inhibition: 6340 nM
Compound 3: middle estimate off by 9.5-fold (0.98 log units), on the high side; the whole stated range lies above it.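

In this assay, the group on a carbonyl carbon whose other neighbours are an amide-type nitrogen in a ring turns out to matter a great deal: phenyl in place of propyl gives an at least 11-fold lower number from compound 2 to compound 3 (1.04 log units; beyond the scatter). With the benzoyl group, compound 3 reads 6340 nM, a measured number that shows real inhibition of growth, so this position can respond strongly to what is placed on it. Compound 2 reads only as a limit and not as a number, so the step gives a floor and its true size remains unknown: the limit of > 70000 nM in this assay, at which 1 of the 3 values shown sits.

Going by these compounds, a single pair cannot separate the part played by the aromatic ring from that of the extra carbon atoms, so it remains open whether a cyclohexyl ring, a pyridine ring or a longer chain such as hexyl on the same carbonyl carbon would behave like phenyl or like propyl. Compound 1 differs from compound 3 in more than one place, so it adds nothing on this change, and a single cell line leaves open whether the step holds in other cells.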